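Chlorophenyl for methylphenyl on the amino-thiazole chalcones

This account rests on a few compounds, and the source may have more. Where it says the series, first, only, none or still open, it means among the compounds named here.

Measured so far:
compound 1, `Cc1nc(Nc2cccc(Cl)c2)sc1C(=O)/C=C/c1ccccc1`: > 25000 nM
compound 2, `Cc1ccccc1Nc1nc(C)c(C(=O)/C=C/c2ccc(Cl)cc2)s1`: > 25000 nM
compound 3, `Cc1ccc(Nc2nc(C)c(C(=O)/C=C/c3ccc(Cl)cc3)s2)cc1`: > 25000 nM

All three measured compounds share the same core and were tested in a functional assay on NCI-H460 cells (Homo sapiens) for cytotoxicity, read by MTT assay; a lower number here means a stronger inhibitor, a higher number a weaker inhibitor. Compound 1 gives only a limit, > 25000 nM, not a number. Compound 2 likewise gives only a limit, > 25000 nM. Compound 3 also stands at a limit, > 25000 nM, so no number is known for it; the change from compound 2 to compound 3, a step that the two limits leave unreadable from compound 2 to compound 3, cannot be read because both values are limits (the limit of > 25000 nM in this assay, at which 3 of the 3 values shown sit).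

The unmeasured compound 4, `Cc1nc(Nc2cccc(Cl)c2)sc1C(=O)/C=C/c1ccc(Cl)cc1`, differs from compound 3 by 3-chlorophenyl in place of 4-methylphenyl on a nitrogen on an aromatic ring. Among the measured compounds shown here, the only measured step that bears on it is the unreadable one, and compound 1, which already carries the 3-chlorophenyl group, sits at the same limit. Compound 4 is therefore expected to remain at that limit as well, with no readable step, a step that the limit leaves unreadable from compound 3 to compound 4. The estimate for compound 4 is 40000 nM, in the range 12000 nM to 150000 nM.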

Compound 4, half-maximal inhibitory concentration: > 25000 nM
Compound 4 gave a limit, no number (the forecaster's own chance of this, stated with the estimate: 85%); the middle value lies beyond the limit too.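

Compound 4 also gives only a limit, so no step among compound 1, compound 2, compound 3 and compound 4 can be read, because all of them sit at the same limit: the limit of > 25000 nM in this assay, at which 4 of the 4 values shown sit.

The compounds shown leave open whether any change on the shared core gives a readable value, and how the 3-chlorophenyl, 2-methylphenyl and 4-methylphenyl groups compare.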